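A few compounds are considered here, and "the series" means these few. Any claim that something is new, unique, unknown or untested is made for them only; others in the source may bear on it.

Measured compounds:
- compound 2 `CCCN1C(=O)/C(=C\C(=O)C[C@@H]2O[C@H](COC(C)=O)[C@@H](OC(C)=O)[C@H](OC(C)=O)[C@H]2OC(C)=O)c2ccccc21`: 125000 nM
- compound 3 `CCCCN1C(=O)/C(=C\C(=O)C[C@@H]2O[C@H](COC(C)=O)[C@@H](OC(C)=O)[C@H](OC(C)=O)[C@H]2OC(C)=O)c2ccccc21`: 126000 nM
- compound 1 `CC(=O)OC[C@H]1O[C@@H](CC(=O)CC2(O)C(=O)N(Cc3ccccc3)c3ccc(Cl)cc32)[C@H](OC(C)=O)[C@@H](OC(C)=O)[C@@H]1OC(C)=O`: "not determined" (no result reported)

In an ADME assay on Vero cells (Chlorocebus sabaeus) for cytotoxicity, read by resazurin assay, with a stated time of 72 h (a higher number here means that more compound is tolerated, a lower number that less compound is tolerated), compound 2 gives 125000 nM and compound 3 gives 126000 nM. The step of a 1.0-fold higher number from compound 2 to compound 3 (0.00 log units; within the scatter) shows that lengthening the chain on the ring nitrogen left the tolerated concentration unchanged. Compound 3 therefore stands level with compound 2 on the two numbers available, and compound 1 adds no number to compare against.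

Compound 4 `CC(=O)OC[C@H]1O[C@@H](CC(=O)/C=C2\C(=O)N(Cc3ccccc3)c3ccccc32)[C@H](OC(C)=O)[C@@H](OC(C)=O)[C@@H]1OC(C)=O` differs from compound 3 by phenyl in place of propyl on a saturated chain carbon bound to an amide-type nitrogen in a ring. Within the data shown here, the only measured step, from compound 2 to compound 3, concerns a change of chain length at the same place and was flat, so it gives no indication that substitution on this nitrogen moves the read-out; it does not, however, cover an aromatic ring entering there. Among the measured compounds shown here, with no step bearing directly on a phenyl for propyl exchange, the expectation is that compound 4 stays close to compound 3, with the estimated step of a 1.3-fold lower number from compound 3 to compound 4 (0.10 log units; within the scatter) lying within the scatter. Compound 4 is thus expected to give 100000 nM, in the range 40000 nM to 250000 nM.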

Compound 4, half-maximal cytotoxic concentration: 71200 nM
The estimate for compound 4 lay 1.4-fold (0.15 log units) above the measured number; measured number inside the range.
By their numbers in this assay, from the lowest: compounds 4, 2 and 3 (each within the scatter of the next).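

Replacing the plain chain with an aromatic ring on the saturated chain carbon bound to the amide-type nitrogen gives, in this assay, a 1.8-fold lower number from compound 3 to compound 4 (0.25 log units; within the scatter) and stays inside that scatter. Measured against the shorter chain, the same kind of exchange gives a 1.8-fold lower number from compound 2 to compound 4 (0.24 log units; within the scatter) and leads to the same reading, so this position has now been probed with a ring as well as with chains of different length, and neither kind of change has moved the number beyond the scatter. No measurement offered here accounts for this flat picture.

From the compounds shown here alone, whether an amine or a carboxylic acid at this same place would also leave the number within the scatter remains open. So does the outcome for a much longer chain, such as octyl, or for a phenyl ring carrying a methoxy group.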